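Swapping hydroxy for dimethylamino on compound 2

A few compounds are considered here, and "the series" means these few. Any claim that something is new, unique, unknown or untested is made for them only; others in the source may bear on it.

Compound 1 `COc1ccc(C(=O)c2ccc(OC)c3c2C=CC(C)(C)O3)c(NC(=O)CBr)c1`: 4360 nM
Compound 2 `COc1ccc(C(=O)c2ccc3c(c2)C=CC(C)(C)O3)c(NC(=O)CO)c1`: 250 nM
Compound 3 `CCNCC(=O)Nc1cc(OC)ccc1C(=O)c1ccc(OC)c2c1OC(C)(C)C=C2`: 3690 nM

In a functional assay on HCT-8 cells (Homo sapiens) for antiproliferative activity, read by MTT assay, with a stated time of 48 h (a lower number here means a stronger inhibitor, a higher number a weaker inhibitor), compound 2 gives 250 nM, the lowest of the three numbers. The values of compound 3 and compound 1 both lie above it, beyond the usual scatter, and they sit within the scatter of each other.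

The next compound, compound 4 `COc1ccc(C(=O)c2ccc3c(c2)C=CC(C)(C)O3)c(NC(=O)CN(C)C)c1`, has dimethylamino in place of hydroxy on a saturated chain carbon bound to a carbonyl carbon. For the measured compounds named here, no two measured compounds differ in just one place, so the data give no direct guide to the size of this step. Compound 3, which also has an amino group in its side chain, gives 3690 nM. That is only a weak hint, since compound 1 has no such amino group and gives 4360 nM. A moderate weakening is therefore expected, and the estimated 4.0-fold higher number from compound 2 to compound 4 (0.60 log units; beyond the scatter) is a rise in the number. For compound 4 the estimated value is 1000 nM, with an expected range from 200 nM to 5000 nM.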

Compound 4, half-maximal inhibitory concentration: 2420 nM
Beside the measured number, compound 4's estimate is 2.4-fold (0.38 log units) below it; measured number inside the range.
By their numbers in this assay, from the lowest: compound 2; then compounds 4, 3 and 1 (each within the scatter of the next).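

In this assay, for the compounds shown here, the exchange of hydroxy for dimethylamino on a saturated chain carbon bound to a carbonyl carbon gives a 9.7-fold higher number from compound 2 to compound 4 (0.99 log units; beyond the scatter) and is the first direct reading of a single change at this place. It shows that the group on this carbon matters for the measured number, even though the rest of the molecule stays the same. The exchange both removes a hydrogen-bond donor and adds heavy atoms, so this one pair cannot separate those two differences, and no measurement shown accounts for the rise.

Still open, as far as these compounds go, is how a methoxy group, a smaller amine such as methylamino, or a longer chain ending in dimethylamino would read on this carbon. Also open, from the compounds shown here alone, is whether the same exchange would give a step of similar size on the core of compound 3.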